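A few compounds are considered here, and "the series" means these few. Any claim that something is new, unique, unknown or untested is made for them only; others in the source may bear on it.

Compound 3 `COc1ccc(C(=O)c2sc(Nc3ccccc3)c(C(=O)O)c2C)cc1` gives 36.5% in a functional assay, with a stated time of 150 min, tested at 15 ug/mL (a higher number here means a stronger effect of the compound at the concentration tested, a lower number a weaker effect), the highest of the three numbers at hand. Compound 1 `COC(=O)c1c(Nc2ccccc2)sc(C(=O)c2ccc(OC)cc2)c1C` stands nearest, giving 28.6% in this assay, and a number 7.9 percentage points higher from compound 1 to compound 3 (within the scatter). Compound 2 `COC(=O)c1c(Nc2ccc(F)cc2)sc(C(=O)c2ccc(OC)cc2)c1C` stands furthest, giving 15.2%. Compound 4 `COc1ccc(Nc2sc(C(=O)c3ccc(OC)cc3)c(C)c2C(=O)O)cc1` differs from compound 3 by methoxy in place of hydrogen on an aromatic carbon. For the measured compounds named here, the step that bears on this is the substitution on an aromatic carbon, a number 13.4 percentage points lower from compound 1 to compound 2 (beyond the scatter); no step with methoxy entering is known. A modest lowering, or no step beyond the scatter, is therefore expected, a number 8.5 percentage points lower from compound 3 to compound 4 (within the scatter). Compound 4 is estimated to give 28% in this assay, within a range from 12% to 44%.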

Compound 4, a percentage reported as activity, at one concentration (the size of the read-out at that concentration, not a potency): 30.6%
Estimate against measurement, compound 4: 2.6 percentage points below; the range from low to high includes it.
By their numbers in this assay, from the lowest: compound 2; then compounds 1, 4 and 3 (each within the scatter of the next).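

In this assay, methoxy on this aromatic carbon, para to a large group, gives a small shift (a number 5.9 percentage points lower from compound 3 to compound 4 (within the scatter)). Fluoro at the same place, on a different parent, gave a clearer one (a number 13.4 percentage points lower from compound 1 to compound 2 (beyond the scatter)), so a substituent here does not always move the number beyond the scatter. Nothing measured explains the difference between these two steps. Going by these compounds, it remains open whether fluoro would act the same way on compound 3, and whether an amine or ethoxy at this place would behave like methoxy.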